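From 3-chlorophenyl to 4-chlorophenyl: a chlorine moved

The compounds below may be only part of what the source reports. "The series", "measured", "known", "first", "only" and "open" are said of these compounds alone.

In a functional assay on UACC-62 cells (Homo sapiens) for cytotoxicity, read by sulforhodamine B assay (on this read-out higher numbers stand for weaker inhibition of growth and lower numbers for stronger inhibition of growth), compound 1 `CC1=CC[C@@H]([C@@](C)(O)CCCC(C)(C)NC(=S)NN)CC1` gives > 100000 nM, which is a limit of the assay and not a number. Within the data shown here, compound 2 `CC1=CC[C@@H]([C@@](C)(O)CCCC(C)(C)NC(=S)N/N=C\c2cccc(Cl)c2)CC1` gives 18100 nM, the only true number so far. Among the measured compounds shown here, the one measured step is an at least 5.5-fold lower number from compound 1 to compound 2 (0.74 log units; beyond the scatter). As far as these compounds go, it brings in the whole 3-chlorophenyl group, and its full size stays open, as the limit of > 100000 nM in this assay, at which 1 of the 2 values shown sits, marks one end of it.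

Compound 3 `CC1=CC[C@@H]([C@@](C)(O)CCCC(C)(C)NC(=S)N/N=C\c2ccc(Cl)cc2)CC1` follows from compound 2 with one change: 4-chlorophenyl in place of 3-chlorophenyl on a carbon with a double bond to nitrogen. In words, 4-chlorophenyl stands in place of 3-chlorophenyl on a carbon with a double bond to nitrogen. The measured step from compound 1 bears on this only loosely, since it adds the chlorinated ring and does not move the chlorine. For the measured compounds named here, no measured pair shows what such a move does, so no direction can be argued and no shift beyond the scatter is expected. The estimated change is a 1.1-fold lower number from compound 2 to compound 3 (0.05 log units; within the scatter), which is expected to lie within the scatter. Compound 3 is expected to give about 16000 nM, with an estimated range from 7000 nM to 40000 nM.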

Compound 3, concentration for total growth inhibition: 13800 nM
Compound 3: the middle estimate sits 1.2-fold (0.06 log units) above what was measured; measured number inside the range.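

In this assay, the change to 4-chlorophenyl in place of 3-chlorophenyl, on a carbon with a double bond to nitrogen, gives a 1.3-fold lower number from compound 2 to compound 3 (0.12 log units; within the scatter), so this move of the chlorine around the ring leaves no difference that can be told from the scatter. The chlorinated ring in its new arrangement also stands clearly apart from the compound without it, with an at least 7.2-fold lower number from compound 1 to compound 3 (0.86 log units; beyond the scatter), and this now holds for both chlorophenyl groups shown. As far as these compounds go, for compound 1, > 100000 nM is a limit of the assay and not a number, so the full size of this step stays open: the limit of > 100000 nM in this assay, at which 1 of the 3 values shown sits.

The compounds shown carry only chlorophenyl groups on this carbon, so they leave open what plain phenyl, 2-chlorophenyl, a methoxyphenyl or a pyridine ring would give in the same place, and whether the chlorine itself matters at all. From the compounds shown here alone, all of them also share the same core, so the effect of a change there, such as an amine in place of its hydroxyl, remains unknown as well.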